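This account rests on a few compounds, and the source may have more. Where it says the series, first, only, none or still open, it means among the compounds named here.

Measured so far:
compound 1 `Cc1ccc(S(=O)(=O)N[C@@H](CC(=O)NC(C)(C)C)C(=O)NCCNC(=O)NCc2ccccc2)cc1` — in an ADME assay on Karpas-1106P cells (Homo sapiens) for cytotoxicity (a higher number here means that more compound is needed for the effect, a lower number that less compound is needed), compound 1 gives > 11100 nM, which is a limit of the assay.
compound 2 `Cc1ccc(S(=O)(=O)N[C@@H](CC(=O)NC(C)(C)C)C(=O)NCCNC(=O)c2cc(Cl)ccc2Cl)cc1` — compound 2 gives > 11100 nM, again a limit.
compound 3 `Cc1ccc(S(=O)(=O)N[C@@H](CC(=O)NC(C)(C)C)C(=O)NCCNC(=O)c2cc(Cl)ccn2)cc1` — compound 3 gives > 11100 nM, also a limit.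

Compound 3 therefore stands only as a limit, and the two further values shown are limits as well, all at the limit of > 11100 nM in this assay, at which 3 of the 3 values shown sit. Compound 4 `COc1cc(OC)cc(C(=O)NCCNC(=O)[C@H](CC(=O)NC(C)(C)C)NS(=O)(=O)c2ccc(C)cc2)c1` differs from compound 3 by 3,5-dimethoxyphenyl in place of 4-chloropyridin-2-yl on a carbonyl carbon. For the measured compounds named here, the steps that bear on it, a step that the two limits leave unreadable from compound 1 to compound 3 and a step that the two limits leave unreadable from compound 2 to compound 3, as well as a step that the two limits leave unreadable from compound 1 to compound 2, are unreadable from the two limits, so no size can be read for a change on this carbonyl carbon. The step that the limit leaves unreadable from compound 3 to compound 4 is expected to be none beyond the scatter, most likely ending at the same limit. Compound 4 is estimated at 20000 nM, between 8000 nM and 50000 nM.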

Compound 4, half-maximal effective concentration: > 11100 nM
Compound 4: only a limit was reported; the forecaster's own chance of this, stated with the estimate: 85%; the middle value lies beyond the limit too.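

In this assay compound 4 gives > 11100 nM, a limit of the assay. For the compounds shown here, no step from compound 1, compound 2 or compound 3 to compound 4 can be read: the limit of > 11100 nM in this assay, at which 4 of the 4 values shown sit. The compounds shown leave open whether any group on this carbonyl carbon gives a measurable value.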